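The source may hold more compounds than are shown below. What is called first, only, known or untested is meant among the compounds shown, and "the series" means these compounds.

Within the data shown here, compound 2, with the structure `CCOc1ccc(S(=O)(=O)NC(=O)Nc2ccc(Cl)cc2)s1`, gives 69% in a functional assay on the whole organism (6C3HED cells, Mus musculus) for inhibition, at a dose of 150 mg/kg by the oral route (a higher number here means more inhibition at the dose given (going by the name of the read-out), a lower number less inhibition), and this is the higher of the two numbers known so far. The other measured compound, compound 1, `O=C(Nc1ccc(Cl)cc1)NS(=O)(=O)c1cccs1`, gives 16% in this assay. Among the measured compounds shown here, the one measured step, a number 53 percentage points higher from compound 1 to compound 2 (beyond the scatter), is large and carries the change of ethoxy in place of hydrogen on an aromatic carbon of the shared core. Compound 3, `CCCc1ccc(S(=O)(=O)NC(=O)Nc2ccc(Cl)cc2)s1`, is the next compound to be measured, and it differs from compound 2 as follows: propyl in place of ethoxy on an aromatic carbon. For the measured compounds named here, no measured step exchanges ethoxy for propyl, so the step from compound 1 to compound 2 bears on it only in showing that a large group on that ring carbon brings the high number of compound 2. The propyl is counted as a group of the same size, so the estimated step of a number 14 percentage points lower from compound 2 to compound 3 (beyond the scatter) is expected to be small, likely downward. Compound 3 is therefore estimated at 55% in this assay, within a range from 30% to 80%.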

Compound 3, a percentage reported as inhibition, in the whole organism at one dose (the size of the read-out at that dose, not a potency): 38%
Beside the measured number, compound 3's estimate is 17 percentage points above it, within the range that was stated.
By their numbers in this assay, from the lowest: compound 1; then compound 3; then compound 2.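

In this assay, the group at this ring carbon matters beyond its size: a number 31 percentage points lower from compound 2 to compound 3 (beyond the scatter), although ethoxy and propyl have the same count of heavy atoms and differ in that ethoxy holds an oxygen and a hydrogen-bond acceptor. The gain over hydrogen does not need that oxygen, since a number 22 percentage points higher from compound 1 to compound 3 (beyond the scatter), a modest step against the large one to compound 2. Nothing measured here explains why the two groups part in this way.

As far as these compounds go, whether a methoxy, an amine or a longer chain at this ring carbon would stand nearer compound 2 or compound 3 stays open. From the compounds shown here alone, the rest of the shared core is the same in all three compounds, so it is also open whether these steps would hold with a change elsewhere.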